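A few compounds are considered here, and "the series" means these few. Any claim that something is new, unique, unknown or untested is made for them only; others in the source may bear on it.

In a functional assay on A549 cells (Homo sapiens) for cytotoxicity, read by MTT assay, with a stated time of 48 h (a lower number here means a stronger inhibitor, a higher number a weaker inhibitor), compound 1 (`CCN(CC)CCCOc1c(O)cc(O)c2c(=O)cc(-c3ccccc3)oc12`) gives > 100000 nM and this is a limit of the assay, not a number. Compound 2 (`CC(CO)NCCOc1c(O)cc(O)c2c(=O)cc(-c3ccccc3)oc12`) has no single number, its entry being "not determined" (no result reported) with nothing to place it on the scale. Going by the values given here, the series so far therefore offers only the limit of > 100000 nM in this assay, at which 1 of the 2 values shown sits, and no measured step. Compound 3 (`CN1CCN(CCCOc2c(O)cc(O)c3c(=O)cc(-c4ccccc4)oc23)CC1`) carries the change (4-methylpiperazin-1-yl)methyl in place of (1-(hydroxymethyl)ethyl)amino on a saturated chain carbon, two bonds along the chain from an oxygen on an aromatic ring and so has (4-methylpiperazin-1-yl)methyl in place of (1-(hydroxymethyl)ethyl)amino on a saturated chain carbon, two bonds along the chain from an oxygen on an aromatic ring. With compound 1 at > 100000 nM only a small step toward stronger inhibition is expected in this assay and the result may well stay at the limit. For compound 3 the estimated value is 60000 nM with an expected range from 20000 nM to 100000 nM in these notes.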

Compound 3, half-maximal inhibitory concentration: > 100000 nM
Compound 3: only a limit was reported (the forecaster's own chance of this, stated with the estimate: 50%); middle value at least 1.6-fold (0.22 log units) away from the limit.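

Compound 1 and compound 3 both end at a limit of the assay in this assay, so no step between them can be read: the limit of > 100000 nM in this assay, at which 2 of the 3 values shown sit.

The compounds shown leave open whether any side chain on the shared core gives a readable value in this assay.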